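This account rests on a few compounds, and the source may have more. Where it says the series, first, only, none or still open, it means among the compounds named here.

Among the compounds with values here, compound 3, with the structure `Nc1sc(-c2ccc(F)cc2)c(-c2ccc(Cl)cc2)c1C(=O)NC1CC1`, is one of three compounds measured in a functional assay on PC-3 cells (Homo sapiens) for cytotoxicity, read by sulforhodamine B assay, with a stated time of 72 h (a lower number here means a stronger inhibitor, a higher number a weaker inhibitor), where compound 3 gives 28000 nM. That is the highest of the three numbers, but its gap to compound 1, the structure `Nc1sc(-c2ccccc2)c(-c2ccc(Cl)cc2)c1C(=O)N1CCCC1`, which in this assay gives 22200 nM, lies within the scatter; only compound 2, the structure `Nc1sc(-c2ccc(Cl)cc2)c(-c2ccc(Cl)cc2)c1C(=O)N1CCCC1`, stands clearly apart, giving 6220 nM in this assay.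

The step to compound 4, the structure `Nc1sc(-c2ccc(F)cc2)c(-c2ccc(Cl)cc2)c1C(=O)N1CCCC1`, changes the amide: pyrrolidin-1-yl in place of cyclopropylamino on a carbonyl carbon. Within the data shown here, no measured step touches this part of the molecule. Among the measured compounds shown here, the one step recorded, a 3.6-fold lower number from compound 1 to compound 2 (0.55 log units; beyond the scatter), concerns a halogen on an aromatic ring and carries over only indirectly: compound 4 shares the pyrrolidine amide of compound 1 and compound 2 and differs from each of them in the para substituent of one aryl ring alone, so its number is plausibly bracketed by the values of compound 1 and compound 2.

For the measured compounds named here, with no direct precedent, a step of modest size toward a lower number, a 2.3-fold lower number from compound 3 to compound 4 (0.37 log units; beyond the scatter), is expected rather than a large one. Compound 4 is therefore estimated at 12000 nM in this assay, with a range from 4000 nM to 35000 nM.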

Compound 4, half-maximal inhibitory concentration: 20400 nM
Estimate against measurement, compound 4: 1.7-fold (0.23 log units) below; the range from low to high includes it.
By their numbers in this assay, from the lowest: compound 2; then compounds 4, 1 and 3 (each within the scatter of the next).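

In this assay, pyrrolidin-1-yl in place of cyclopropylamino on a carbonyl carbon gives a 1.4-fold lower number from compound 3 to compound 4 (0.14 log units; within the scatter), so this amide change, in which a group with 1 hydrogen-bond donor gives way to one with 0, shows no difference beyond the scatter on the fluoro compounds. The halogen result is sharper: fluoro in place of chloro on an aromatic carbon gives a 3.3-fold higher number from compound 2 to compound 4 (0.52 log units; beyond the scatter), whereas fluoro in place of hydrogen gives a 1.1-fold lower number from compound 1 to compound 4 (0.04 log units; within the scatter), so among the pyrrolidine amides, the chloro compound alone stands apart, and the fluoro and unsubstituted compounds cannot be told apart. Nothing measured here offers an explanation for either result.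

Within the data shown here, the single amide step rests on the fluoro compounds, so whether the same amide change would stay within the scatter with chloro on the aromatic carbon remains open. Also open, on these data alone, is how morpholin-4-yl or diethylamino on the carbonyl carbon, or bromo or methoxy on the aromatic carbon, would compare in this assay.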